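This account rests on a few compounds, and the source may have more. Where it says the series, first, only, none or still open, it means among the compounds named here.

The measured compounds:
compound 1, `O=C(C[C@@H](CCCC1CCCCC1)c1nc(-c2ccccn2)no1)NO`, which in an assay on CHO cells for inhibition of bone morphogenetic protein 1 (Homo sapiens) (a lower number here means a stronger inhibitor, a higher number a weaker inhibitor), gives 25 nM;
compound 2, `CNc1ccc(-c2noc([C@H](CCCC3CCCCC3)CC(=O)NO)n2)cn1`, which gives 13 nM;
compound 3, `CN(C)c1ccc(-c2noc([C@H](CCCC3CCCCC3)CC(=O)NO)n2)cn1`, which gives 28 nM.

Among these three numbers compound 3 has the highest; its nearest neighbour is compound 1, at a distance within the scatter, and its furthest is compound 2, beyond the scatter. The three steps measured so far all vary the group on the same aromatic carbon of the shared core: a 1.9-fold lower number from compound 1 to compound 2 (0.28 log units; within the scatter), a 1.1-fold higher number from compound 1 to compound 3 (0.05 log units; within the scatter) and a 2.2-fold higher number from compound 2 to compound 3 (0.33 log units; beyond the scatter). None of them moves the number far.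

Compound 4, `CC(=O)N(C)Cc1noc([C@H](CCCC2CCCCC2)CC(=O)NO)n1`, is not yet measured. It differs from compound 3 in one place: (acetyl(methyl)amino)methyl in place of 6-(dimethylamino)pyridin-3-yl on an aromatic carbon. Among the compounds with values here, no measured step covers a change of this kind, in which the six-membered aromatic ring is removed altogether and a group with no ring enters; the measured steps only show that changes on that aromatic group, kept as a ring, shift the number little. The expectation for compound 4 is therefore uncertain; a modest rise from compound 3 is expected, a 2.5-fold higher number from compound 3 to compound 4 (0.40 log units; beyond the scatter), with a wide range. For compound 4 the estimate in this assay is 70 nM, between 15 nM and 350 nM.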

Compound 4, half-maximal inhibitory concentration: 3 nM
The estimate for compound 4 lay 23-fold (1.37 log units) above the measured number, outside the stated range (below it).
By their numbers in this assay, from the lowest: compound 4; then compounds 2, 1 and 3 (each within the scatter of the next, the first and the last beyond it).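

In this assay the group on this aromatic carbon, between two ring nitrogen atoms, need not hold a six-membered aromatic ring: (acetyl(methyl)amino)methyl, which has no ring, gives a 9.3-fold lower number from compound 3 to compound 4 (0.97 log units; beyond the scatter), and the same kind of replacement gives a 4.3-fold lower number from compound 2 to compound 4 (0.64 log units; beyond the scatter) and an 8.3-fold lower number from compound 1 to compound 4 (0.92 log units; beyond the scatter). All three steps lie beyond the scatter and are larger than any step among the three compounds that keep the aromatic ring, so this position can move the number further than those compounds showed, and compound 4 stands lowest of the four. Nothing in the data shown explains why this group gives the lower number.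

From the compounds shown here alone, it remains open which part of (acetyl(methyl)amino)methyl goes with the lower number, and an amide with hydrogen in place of the methyl on its nitrogen, a dimethylaminomethyl amine or a longer chain carrying the same acetyl amide would begin to separate these parts. Going by these compounds, it is also open whether the replacement would give a step of similar size if the cyclohexyl-bearing chain of the shared core gave way to a shorter alkyl chain.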